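Removing one methyl from a propanoyl side chain

This account rests on a few compounds, and the source may have more. Where it says the series, first, only, none or still open, it means among the compounds named here.

Compound 1, `CCC(=O)c1ccc2c(c1O)[C@H]1c3c(ccc4c(=O)c(C)coc34)OC[C@H]1C(C)(C)O2`, and compound 2, `CC(=O)c1ccc2c(c1O)[C@H]1c3c(ccc4c(=O)c(C)coc34)OC[C@H]1C(C)(C)O2`, share a core and differ in a single place: hydrogen in place of methyl on a saturated chain carbon bound to a carbonyl carbon. In a functional assay on A549 cells (Homo sapiens) for cytotoxicity, read by MTT assay (a lower number here means a stronger inhibitor, a higher number a weaker inhibitor), compound 1 gives > 100000 nM, which is a limit of the assay rather than a number. Compound 2 likewise gives > 100000 nM in this assay, again a limit. The step between them, a step that the two limits leave unreadable from compound 1 to compound 2, therefore cannot be sized due to the limit of > 100000 nM in this assay, at which 2 of the 3 values shown sit.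

Compound 3, `CCC(=O)c1ccc2c(c1O)[C@@H]1c3c(ccc4c(=O)c(-c5ccccc5)c(C)oc34)OC[C@@H]1C(C)(C)O2`, carries a different core; the difference between the core of compound 3 and the core of compound 1 is not broken down here. In this assay, among the compounds with values here, compound 3 gives 19300 nM, the only actual number among the three measured compounds.

Compound 4, `CC(=O)c1ccc2c(c1O)[C@@H]1c3c(ccc4c(=O)c(-c5ccccc5)c(C)oc34)OC[C@@H]1C(C)(C)O2`, is related to compound 3 by the same change that relates compound 1 to compound 2: hydrogen in place of methyl on a saturated chain carbon bound to a carbonyl carbon. The place is the same word for word in both pairs, so it is the same change.

For compound 4 the expected value in this assay is 25000 nM, with a range from 9000 nM to 80000 nM. The expected step is a 1.3-fold higher number from compound 3 to compound 4 (0.11 log units; within the scatter), which is estimated to stay within the usual scatter. This rests on the value of compound 3, 19300 nM, and on the step that the two limits leave unreadable from compound 1 to compound 2, whose size cannot be read and so gives no ground for expecting a large shift in either direction.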

Compound 4, half-maximal inhibitory concentration: 2530 nM
Beside the measured number, compound 4's estimate is 9.9-fold (0.99 log units) above it, and the stated range ends above it.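

In this assay, the change from propanoyl to acetyl gives a 7.6-fold lower number from compound 3 to compound 4 (0.88 log units; beyond the scatter), a step beyond the usual scatter, and this is a reading on one core only. The identical change on the core of compound 1 joins compound 1 to compound 2, but neither end of that pair gives a number, and the step between them cannot be read because both compounds sit at a limit: the limit of > 100000 nM in this assay, at which 2 of the 4 values shown sit. The series therefore shows that this change can go with a clear shift on one core, but it does not show that the step carries over to the other core or that it fails to, and the unreadable pair gives no size to set against it.

The compounds shown leave open whether the number would keep moving along the chain, as a butanoyl group, with its longer chain, might show against propanoyl and acetyl on the core of compound 3. They also leave open how a quite different group in the same place, such as an amine or a carboxylic acid, would read in this assay, and whether any such group would bring the core of compound 1 away from its limit.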